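Notes on the amine swap at the thiocarbonyl carbon

The compounds below may be only part of what the source reports. "The series", "measured", "known", "first", "only" and "open" are said of these compounds alone.

Measured so far:
compound 1, `Nc1ccccc1NC(=O)c1ccc(CSC(=S)N2CCc3ccccc32)cc1`, 87%
compound 2, `Nc1ccccc1NC(=O)c1ccc(CSC(=S)N2CCN(c3cccnc3)CC2)cc1`, 76.9%
compound 3, `Nc1ccccc1NC(=O)c1ccc(CSC(=S)N2CCN(c3ccc(F)cc3)CC2)cc1`, 48.7%

In a functional assay on MGC-803 cells (Homo sapiens) for antiproliferative activity, read by CCK-8 assay, with a stated time of 72 h, tested at 8 uM (on this read-out lower numbers stand for a weaker effect and higher numbers for a stronger effect at the one concentration tested), compound 1 stands highest of the three; compound 2 sits nearest, lower by a step beyond the scatter, and compound 3 furthest, also beyond the scatter. Within the data shown here, the one step between compounds that differ in a single place is a number 28.2 percentage points lower from compound 2 to compound 3 (beyond the scatter), a change of the aryl group on an amine nitrogen in a ring.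

Compound 4, `CN(Cc1ccncc1)C(=S)SCc1ccc(C(=O)Nc2ccccc2N)cc1`, differs from compound 1 by methyl((pyridin-4-yl)methyl)amino in place of 2,3-dihydro-1H-indol-1-yl on a thiocarbonyl carbon. Among the measured compounds shown here, no measured pair follows this kind of change: the step from compound 2 to compound 3 alters a substituent on a ring amine, whereas here the ring amine itself is exchanged for an open-chain one. The pyridinyl-bearing compound 2 does give a higher number than compound 3, which is the only hint that a pyridine-containing amine is tolerated. Given that the pair with the nearest precedent moved by a modest step, a modest decrease is expected, estimated as a number 17 percentage points lower from compound 1 to compound 4 (beyond the scatter). For compound 4 the expected value in this assay is 70%, with a range from 50% to 88%.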

Compound 4, a percentage reported as inhibition, at one concentration (the size of the read-out at that concentration, not a potency): 83.2%
Compound 4: the middle estimate sits 13.2 percentage points below what was measured; measured number inside the range.
By their numbers in this assay, from the lowest: compound 3; then compounds 2, 4 and 1 (each within the scatter of the next, the first and the last beyond it).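

At the thiocarbonyl carbon, methyl((pyridin-4-yl)methyl)amino in place of 2,3-dihydro-1H-indol-1-yl gives a number 3.8 percentage points lower from compound 1 to compound 4 (within the scatter) in this assay, so the two groups cannot be told apart on this read-out. This position therefore accepts an open-chain amine as well as a ring amine, whereas the earlier single-place step concerned only the aryl group on an amine nitrogen in a ring. Nothing available gives a reason for this result.

Going by these compounds, whether the open-chain amine needs its pyridine ring remains open, and a benzyl(methyl)amino group on the thiocarbonyl carbon would address that directly. On these data alone, it is also open whether a smaller open-chain amine such as dimethylamino, or a ring amine such as morpholin-4-yl, would fit this position equally well.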